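Replacing the (1H-tetrazol-5-yl)methyl group on the chain carbon

A few compounds are considered here, and "the series" means these few. Any claim that something is new, unique, unknown or untested is made for them only; others in the source may bear on it.

In an ADME assay on microsomes from liver (Homo sapiens) for metabolic stability (on this read-out higher numbers stand for a longer-lived compound and lower numbers for a shorter-lived compound), compound 1 (`CC(C)C(Cc1nnc[nH]1)c1ccc(-c2ccc3cccc(F)c3c2)[nH]c1=O`) gives 0.307 h. Compound 2 (`CC(C)C(Cc1nnn[nH]1)c1ccc(-c2ccc3cccc(F)c3c2)[nH]c1=O`) gives > 3 h, which is a limit of the assay and not a number. Its position therefore rests only on (the limit of > 3 h in this assay, at which 1 of the 2 values shown sits).

Compound 3 (`CC(C)C(c1noc(=O)[nH]1)c1ccc(-c2ccc3cccc(F)c3c2)[nH]c1=O`) differs from compound 2 as follows: a group of 6 heavy atoms (2 carbon, 2 nitrogen, 2 oxygen; one five-membered aromatic ring with 3 hetero atoms) in place of a group of 6 heavy atoms (2 carbon, 4 nitrogen; one five-membered aromatic ring with 4 hetero atoms), on a saturated chain carbon bound to an aromatic carbon and a saturated chain carbon. The change lies on a saturated chain carbon bound to an aromatic carbon and a saturated chain carbon.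

Among the compounds with values here, the one measured step that bears on this is an at least 9.7-fold higher number from compound 1 to compound 2 (0.98 log units; beyond the scatter). It shows that exchanging one ring for another on this chain can move the half-life well beyond the scatter. Within the data shown here, no measured step covers the present exchange, so this is only a guide to size, and the range stays wide.

A fall in this assay is expected, since compound 1 without the tetrazole ring gave 0.307 h, though probably not one that reaches so low. The expected change is estimated as an at least 2.0-fold lower number from compound 2 to compound 3 (0.30 log units; that floor lies within the scatter). For compound 3 the half-life is estimated at 1.5 h, with an expected range of 0.4 h to 5 h.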

Compound 3, half-life: > 3 h
Compound 3: a limit, no number (the forecaster's own chance of this, stated with the estimate: 35%); middle value at least 2.0-fold (0.30 log units) away from the limit.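

In this assay compound 3 gives > 3 h which is a limit of the assay and not a number. Against the 4H-1,2,4-triazol-3-yl compound, this exchange on the saturated chain carbon bound to an aromatic carbon and a saturated chain carbon gives an at least 9.7-fold higher number from compound 1 to compound 3 (0.98 log units; beyond the scatter) and so the high read-out of compound 2 is not tied to the (1H-tetrazol-5-yl)methyl group alone, since a group with 2 oxygen and 2 nitrogen atoms reaches the same limit on the shared core. The step between compound 2 and compound 3 cannot be read, and the half-lives of the two cannot be ordered: (the limit of > 3 h in this assay, at which 2 of the 3 values shown sit).

On these data alone, how far either compound lies past the limit stays open, so the series gives no ranking among groups that reach it. Also open, as far as these compounds go, is how a carboxylic acid or an amine on the same chain carbon would read in this assay and whether a longer chain between that carbon and the ring would keep the gain over compound 1.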